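Cyclopropylmethyl in place of propyl on the shared core

A few compounds are considered here, and "the series" means these few. Any claim that something is new, unique, unknown or untested is made for them only; others in the source may bear on it.

For the measured compounds named here, compound 1 (`CCCCOc1ncc(S(=O)(=O)N2CCN(CC)CC2)cc1-c1nc2c(CC)n(CCN(C)C)nc2c(=O)[nH]1`) and compound 2 (`CCCn1nc2c(=O)[nH]c(-c3cc(S(=O)(=O)N4CCN(CC)CC4)cnc3OCCOC)nc2c1CC`) are the two measured members. In a physicochemical assay for lipophilicity, at pH 7.4 (on this read-out higher numbers stand for higher lipophilicity and lower numbers for lower lipophilicity), compound 1 gives 3 and compound 2 gives 1 as the lower of the two numbers, a gap beyond the usual scatter.

Compound 3 (`CCc1c2nc(-c3cc(S(=O)(=O)N4CCN(CC)CC4)cnc3OCCOC)[nH]c(=O)c2nn1CC1CC1`) is still unmeasured. Its difference from compound 2 is cyclopropyl in place of ethyl on a saturated chain carbon bound to an aromatic nitrogen and amounts to cyclopropyl in place of ethyl on a saturated chain carbon bound to an aromatic nitrogen. Going by the values given here, no measured pair shows this kind of change, so the expectation starts from compound 2 at 1 as its only anchor. The estimated a number 0.20 log units higher from compound 2 to compound 3 (within the scatter) in this assay is small and upward, within the scatter. For compound 3 the expected value is 1.2 with an estimated range from 0.7 to 1.7 in the same read-out.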

Compound 3, distribution coefficient: 1
Beside the measured number, compound 3's estimate is 0.20 log units above it; low and high end bracket the measured number.
By their numbers in this assay, from the lowest: compounds 2 and 3 (each within the scatter of the next); then compound 1.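

In this assay, cyclopropyl in place of ethyl on a saturated chain carbon bound to an aromatic nitrogen gives no change at the digits printed from compound 2 to compound 3 (within the scatter). For the compounds shown here, this is the only step so far between compounds that differ in one place, so this position now has a direct reading, which the earlier pair, differing in more than one place, could not give: propyl to cyclopropylmethyl, with its three-membered ring of carbon only, leaves the read-out within the scatter. No measured evidence on the compounds accounts for this reading.

Going by these compounds, whether a longer chain such as hexyl, or a chain ending in a carboxylic acid, would move the number beyond the scatter at this position remains open. A single all-carbon step also leaves open whether the same change would read alike on a differently substituted core.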